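The source may report more compounds than this note shows. Statements on the series, on what has been measured and on what is new or still open speak of the compounds shown alone.

Measured so far:
Compound 1 `O=C(/C(=C\c1ccc(O)c([N+](=O)[O-])c1)Sc1ccccc1Br)c1ccc(Br)cc1`: 10000 nM
Compound 2 `O=C(/C(=C\c1ccc([N+](=O)[O-])c(O)c1)Sc1c(F)c(F)c(F)c(F)c1F)c1ccc(Br)cc1`: 10000 nM

In a functional assay on DU-145 cells (Homo sapiens) for inhibition, read by trypan blue exclusion, with a stated time of 96 h (on this read-out lower numbers stand for stronger inhibition of growth and higher numbers for weaker inhibition of growth), compound 2 gives 10000 nM, level with compound 1 at 10000 nM. Within the data shown here, with only these two values, the series offers no measured step to calibrate against.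

Compound 3 `O=C(/C(=C\c1ccc(O)c([N+](=O)[O-])c1)Sc1c(F)c(F)c(F)c(F)c1F)c1ccc(Br)cc1` has the same atoms as compound 2, joined differently: 4-hydroxy-3-nitrophenyl in place of 3-hydroxy-4-nitrophenyl on a double-bonded chain carbon bound to a double-bonded chain carbon. Among the measured compounds shown here, the 4-hydroxy-3-nitrophenyl that enters is also carried by compound 1, which gives 10000 nM, so the one measured compound bearing this group offers no sign of a gain. A step beyond the scatter in this assay is therefore not expected, although a modest move towards stronger inhibition cannot be excluded. The estimated step of a 1.3-fold lower number from compound 2 to compound 3 (0.10 log units; within the scatter) stays within the scatter. Compound 3 is expected at 8000 nM, with an estimated range of 2000 nM to 15000 nM.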

Compound 3, concentration for 50% growth inhibition: 10000 nM
Compound 3: middle estimate off by 1.3-fold (0.10 log units), on the low side, within the range that was stated.
By their numbers in this assay, from the lowest: compounds 1, 2 and 3 (each within the scatter of the next).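

In this assay, the exchange of 3-hydroxy-4-nitrophenyl for 4-hydroxy-3-nitrophenyl on a double-bonded chain carbon bound to a double-bonded chain carbon gives no change at the digits printed from compound 2 to compound 3 (within the scatter), so with 2,3,4,5,6-pentafluorophenyl on the sulfur, this rearrangement of the same atoms leaves no mark on the read-out. Among these compounds, compound 3 also provides the first comparison at the sulfur: with 4-hydroxy-3-nitrophenyl held constant, 2,3,4,5,6-pentafluorophenyl in place of 2-bromophenyl gives no change at the digits printed from compound 1 to compound 3 (within the scatter). No measurement in hand bears on why these values coincide.

Going by these compounds, neither place has yet produced a step beyond the scatter, so whether either can move growth inhibition remains unknown. Open questions include what an amine in place of the nitro group would do, and what a small alkyl chain such as methyl would do on the sulfur.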